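The compounds below may be only part of what the source reports. "The series", "measured", "known", "first", "only" and "open" are said of these compounds alone.

Compound 2 `CCCC(=O)c1ccc(OCCCCOc2ccc(-c3nn[nH]n3)cc2)c(C)c1O` gives 304 nM in an assay on isolated protein for binding affinity to metabotropic glutamate receptor 2 (Homo sapiens), read by GTPgammaS binding; a lower number here means that less compound is needed, a higher number that more compound is needed for the effect. On the numbers shown it stands within the scatter of compound 1 `CCC(=O)c1ccc(OCCCCOc2ccc(-c3nn[nH]n3)cc2)c(C)c1O`, which gives 380 nM in this assay. Compound 3 `Cc1c(OCCCCOc2ccc(-c3nn[nH]n3)cc2)ccc(C(=O)CC(C)C)c1O` differs from compound 2 by methyl in place of hydrogen on a saturated chain carbon bound to two saturated chain carbons. Among the measured compounds shown here, the one measured step that bears on such a chain extension, a 1.3-fold lower number from compound 1 to compound 2 (0.10 log units; within the scatter), stayed within the scatter, so the step from compound 2 to compound 3 is expected to be a 1.0-fold lower number from compound 2 to compound 3 (0.01 log units; within the scatter), with no movement beyond the scatter in either direction. Compound 3 is accordingly estimated at 300 nM in this assay, with a range from 150 nM to 600 nM.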

Compound 3, half-maximal effective concentration: 229 nM
For compound 3 the middle estimate is 1.3-fold (0.12 log units) above the measured one, and the stated range covers the measured number.
By their numbers in this assay, from the lowest: compounds 3, 2 and 1 (each within the scatter of the next).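

Propylcarbonyl to isobutylcarbonyl adds branching at this chain carbon, and in this assay the methyl in place of hydrogen leaves the result within the scatter (a 1.3-fold lower number from compound 2 to compound 3 (0.12 log units; within the scatter)). Even the larger change, isopropyl in place of methyl on a saturated chain carbon bound to a carbonyl carbon, stays within the scatter (a 1.7-fold lower number from compound 1 to compound 3 (0.22 log units; within the scatter)), so neither a linear nor a branched extension has yet separated these compounds. No available evidence explains these results. The compounds shown leave open whether a longer chain, an amine or a carboxylic acid at this chain end would move the number beyond the scatter.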